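Replacing a nitro group with pyridin-2-yl on the shared core

This account rests on a few compounds, and the source may have more. Where it says the series, first, only, none or still open, it means among the compounds named here.

For the measured compounds named here, compound 2 `O=C1NCCN(c2cccc([N+](=O)[O-])c2)N1` gives 49000 nM in an assay on RBL-1 cells for inhibition of Polyunsaturated fatty acid 5-lipoxygenase (Rattus norvegicus) (on this read-out higher numbers stand for weaker inhibition and lower numbers for stronger inhibition), the highest of the two numbers so far, with compound 1 `COc1cccc(N2CCNC(=O)N2)c1` at 47000 nM lying within the scatter of it. Going by the values given here, the only measured step, a 1.0-fold higher number from compound 1 to compound 2 (0.02 log units; within the scatter), changed the same ring position without effect beyond the scatter. Compound 3 `O=C1NCCN(c2cccc(-c3ccccn3)c2)N1` carries the change (pyridin-2-yl in place of nitro on an aromatic carbon). That step offers little guidance for a larger ring entering, so a modest shift in either direction is expected, a 1.6-fold lower number from compound 2 to compound 3 (0.21 log units; within the scatter). Compound 3 is therefore estimated at 30000 nM, within 8000 nM to 110000 nM.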

Compound 3, half-maximal inhibitory concentration: 30000 nM
Beside the measured number, compound 3's estimate shows no gap at the digits printed, within the range that was stated.
By their numbers in this assay, from the lowest: compounds 3, 1 and 2 (each within the scatter of the next).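

In this assay, for the compounds shown here, pyridin-2-yl, the only group here that brings a whole aromatic ring to this position, shows a 1.6-fold lower number from compound 2 to compound 3 (0.21 log units; within the scatter) and also a 1.6-fold lower number from compound 1 to compound 3 (0.19 log units; within the scatter) and so reads no differently from nitro or methoxy. On the shared core, this position has therefore accepted a much larger group without a step beyond the scatter. Nothing measured here explains this result.

As far as these compounds go, what an amine, a carboxylic acid or a longer chain would do at this position stays open. So does whether any group placed here can move the number beyond the scatter.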